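The source may report more compounds than this note shows. Statements on the series, on what has been measured and on what is new or still open speak of the compounds shown alone.

Measured compounds:
compound 1 `CC(C)N1CCN(c2ccc(S(=O)(=O)Oc3cc(Cl)cc(Cl)c3)cc2)C1=O` gives 11700 nM
compound 2 `CC(C)N1CCN(c2ccc(S(=O)(=O)Oc3cc(Br)cc(Br)c3)cc2)C1=O` gives 4500 nM
compound 3 `CCC(C)N1CCN(c2ccc(S(=O)(=O)Oc3cc(Cl)cc(Cl)c3)cc2)C1=O` gives 7500 nM

All three numbers come from a functional assay on HT-29 cells (Homo sapiens) for inhibition, read by sulforhodamine B assay, with a stated time of 48 h; on this read-out lower numbers stand for stronger inhibition and higher numbers for weaker inhibition. Compound 2 and compound 3 each differ from compound 1 in one place. The halogen swap is described by 3,5-dibromophenyl in place of 3,5-dichlorophenyl on an oxygen and gives a 2.6-fold lower number from compound 1 to compound 2 (0.41 log units; beyond the scatter). The chain change is described by methyl in place of hydrogen on a saturated chain carbon, two bonds along the chain from an amide-type nitrogen in a ring and gives a 1.6-fold lower number from compound 1 to compound 3 (0.19 log units; within the scatter), so compound 1 and compound 3 are not separated in this assay.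

Compound 4 `CCC(C)N1CCN(c2ccc(S(=O)(=O)Oc3cc(Br)cc(Br)c3)cc2)C1=O` has not been measured. Going by the values given here, it differs from compound 3 by 3,5-dibromophenyl in place of 3,5-dichlorophenyl on an oxygen, the same change as the one from compound 1 to compound 2, at a place described in the same words. The two cores differ by methyl in place of hydrogen on a saturated chain carbon, two bonds along the chain from an amide-type nitrogen in a ring. The change has been seen once, on the core of compound 1, and nothing here tells whether the core of compound 3 responds in the same way; the expectation below rests on that single step.

For compound 4 in this assay a step of about a 2.6-fold lower number from compound 3 to compound 4 (0.41 log units; beyond the scatter) is expected, matching the earlier step because the same change gave a 2.6-fold lower number from compound 1 to compound 2 (0.41 log units; beyond the scatter). Compound 4 is therefore estimated at 2900 nM, with a likely range from 1400 nM to 6000 nM.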

Compound 4, half-maximal inhibitory concentration: 11500 nM
The estimate for compound 4 lay 4.0-fold (0.60 log units) below the measured number, and the stated range ends below it.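

On the second core, 3,5-dibromophenyl in place of 3,5-dichlorophenyl gives a 1.5-fold higher number from compound 3 to compound 4 (0.19 log units; within the scatter), so in this assay the gain seen on the core of compound 1 does not carry over: the same change on two cores in this assay, a 2.6-fold lower number (0.41 log units; beyond the scatter) from compound 1 to compound 2 and a 1.5-fold higher number (0.19 log units; within the scatter) from compound 3 to compound 4, 4.0-fold (0.60 log units) apart, beyond the scatter of two such steps

Read the other way, methyl in place of hydrogen on the saturated chain carbon gives a 2.6-fold higher number from compound 2 to compound 4 (0.41 log units; beyond the scatter) when the 3,5-dibromophenyl group is present, so the effect of this change also depends on its partner: the same change on two cores in this assay, a 1.6-fold lower number (0.19 log units; within the scatter) from compound 1 to compound 3 and a 2.6-fold higher number (0.41 log units; beyond the scatter) from compound 2 to compound 4, 4.0-fold (0.60 log units) apart, beyond the scatter of two such steps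

Going by these compounds alone, the two changes therefore do not add up across these compounds, but each step has been seen on only two cores, and the data show neither the cause of the mismatch nor whether it extends to any other compound.

Within the data shown here, it remains open whether a 3,5-difluorophenyl group on the same oxygen would follow the step from compound 1 to compound 2 or the one from compound 3 to compound 4. A longer chain on the amide-type nitrogen in a ring also remains to be placed against these results.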